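The source may report more compounds than this note shows. Statements on the series, on what has been measured and on what is new or still open speak of the compounds shown alone.

Working notes on the series. The shared core is that of compound 1 `O=C1N=C(N2N=C(c3ccccc3)CC2c2ccccc2O)S/C1=C1/C(=O)Nc2ccccc21`, which in a functional assay on cells (Cancer cell lines, Homo sapiens) for cytotoxicity, read by sulforhodamine B assay, with a stated time of 48 h (a higher number here means a weaker inhibitor of growth, a lower number a stronger inhibitor of growth), gives 2410 nM, the highest number among the three measured compounds. Among the compounds with values here, compound 2 `O=C1N=C(N2N=C(c3ccccc3)CC2c2ccccc2O)S/C1=C1/C(=O)Nc2ccc(Br)cc21` gives 280 nM in this assay, and the one-place step an 8.6-fold lower number from compound 1 to compound 2 (0.93 log units; beyond the scatter) is the only measured step in the set. Within the data shown here, compound 3 `COc1ccc(C2CC(c3ccc4ccccc4c3)=NN2C2=NC(=O)/C(=C3\C(=O)Nc4ccc(Br)cc43)S2)cc1` gives 110 nM in this assay; it differs from compound 2 in more than one place, so no single step is drawn from that pair.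

Compound 4 `O=C1N=C(N2N=C(c3ccccc3)CC2c2ccc(Cl)cc2)S/C1=C1/C(=O)Nc2ccccc21` is not yet measured. The change from compound 1 is 4-chlorophenyl in place of 2-hydroxyphenyl on a saturated ring carbon. Among the measured compounds shown here, no measured step touches this position: the step from compound 1 to compound 2 sits on the other aromatic ring, and compound 3 carries a 4-methoxyphenyl at the same saturated ring carbon but together with other changes. For the measured compounds named here, with no step bearing on it, only a small shift is expected, a 1.6-fold lower number from compound 1 to compound 4 (0.21 log units; within the scatter), leaning toward a lower number. Compound 4 is therefore estimated at 1500 nM in this assay, within 500 nM to 5000 nM.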

Compound 4, concentration for 50% growth inhibition: 230 nM
Compound 4: middle estimate off by 6.5-fold (0.81 log units), on the high side; measured number below the stated range.
By their numbers in this assay, from the lowest: compound 3; then compounds 4 and 2 (each within the scatter of the next); then compound 1.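

The saturated ring carbon responds strongly in this assay: with 4-chlorophenyl in place of 2-hydroxyphenyl, the series shows a 10-fold lower number from compound 1 to compound 4 (1.02 log units; beyond the scatter), a large step beyond the scatter and the first single-place step measured at this carbon. The hydrogen-bond donor and acceptor of the leaving group are absent from the entering group, so the higher number of compound 1 does not depend on a need for them at this position, at least for this pair. No available evidence bears on the reason for this step.

The step changes the hydroxyl and the chlorine together, so an unsubstituted phenyl or a 4-hydroxyphenyl at this carbon would be needed to separate the two contributions. From the compounds shown here alone, whether the same step holds alongside the bromo of compound 2 also remains open.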